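The source may report more compounds than this note shows. Statements on the series, on what has been measured and on what is new or still open speak of the compounds shown alone.

Measured in a functional assay on HepG2 cells (Homo sapiens) for antiproliferative activity, read by MTT assay, with a stated time of 48 h; a higher number here means a weaker inhibitor, a lower number a stronger inhibitor
- compound 1 (`COc1ccc(-c2c(Nc3cccc(C(F)(F)F)c3)c3ccccc3oc2=O)cc1`): 66400 nM
- compound 2 (`COc1ccc(-c2c(Nc3ccc(NC(C)=O)cc3)c3ccc(OC)cc3oc2=O)cc1`): > 100000 nM

Compound 2 sits at the limit of > 100000 nM in this assay, at which 1 of the 2 values shown sits, and that is a limit, not a number. Compound 3 (`COc1ccc(-c2c(Nc3cccc(C(F)(F)F)c3)c3ccc(OC)cc3oc2=O)cc1`) has not yet been measured. It keeps the rest of compound 2 and takes 3-(trifluoromethyl)phenyl in place of 4-acetamidophenyl on a nitrogen on an aromatic ring. For the measured compounds named here, no measured pair of compounds shows this change directly. Compound 1 also carries 3-(trifluoromethyl)phenyl and gives 66400 nM, so a modest move toward stronger inhibition is expected in this assay. The estimated change is an at least 1.6-fold lower number from compound 2 to compound 3 (0.22 log units; that floor lies within the scatter), and its size stays loosely fixed with only a limit on one side. For compound 3 the estimated value is 60000 nM, with an expected range from 25000 nM to 100000 nM.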

Compound 3, half-maximal inhibitory concentration: 57300 nM
Beside the measured number, compound 3's estimate is 1.0-fold (0.02 log units) above it; measured number inside the range.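

In this assay, the pair differing by methoxy in place of hydrogen on an aromatic carbon gives a 1.2-fold lower number from compound 1 to compound 3 (0.06 log units; within the scatter), so this change has no effect that can be told from the scatter. With that methoxy kept, 3-(trifluoromethyl)phenyl in place of 4-acetamidophenyl on a nitrogen on an aromatic ring gives an at least 1.7-fold lower number from compound 2 to compound 3 (0.24 log units; that floor lies within the scatter); this change now has a direct reading, but only as a floor. Compound 2 remains a limit, not a number: the limit of > 100000 nM in this assay, at which 1 of the 3 values shown sits.

As far as these compounds go, the true size of the step at the nitrogen stays open, as does whether 4-acetamidophenyl on the core of compound 1 would also give a limit. Also open, from the compounds shown here alone, is how a phenyl ring carrying a carboxylic acid or an amine would read at that nitrogen.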